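Restoring the Nitrogen Methyl While Adding a Nitrile

This account rests on a few compounds, and the source may have more. Where it says the series, first, only, none or still open, it means among the compounds named here.

Among the compounds with values here, compound 2 `Cc1cc(-c2c(C)n[nH]c2C)ccc1-c1nnc(N(C)Cc2ccc3nccn3c2)o1` gives 15800 nM in an assay on COS-7 cells for inhibition of tyrosine-protein kinase receptor UFO (Homo sapiens), read by ELISA, with a stated time of 1 h (a higher number here means a weaker inhibitor, a lower number a stronger inhibitor), the highest of the two numbers so far. Compound 1 `Cc1cc(-c2c(C)nn(C)c2C)ccc1-c1nnc(N(C)Cc2ccc3nccn3c2)o1` gives 398 nM in this assay. Within the data shown here, the one measured step, a 40-fold higher number from compound 1 to compound 2 (1.60 log units; beyond the scatter), shows how much is lost when the methyl on the aromatic nitrogen becomes hydrogen. Compound 3 `Cc1cc(-c2c(C#N)nn(C)c2C)ccc1-c1nnc(N(C)Cc2ccc3nccn3c2)o1` carries 3-cyano-1,5-dimethyl-1H-pyrazol-4-yl in place of 3,5-dimethyl-1H-pyrazol-4-yl on an aromatic carbon. This change reverses that step and also exchanges one methyl for a nitrile, for which no comparison exists. A gain close to the earlier loss is therefore expected, a 32-fold lower number from compound 2 to compound 3 (1.50 log units; beyond the scatter). Compound 3 is estimated at 500 nM, between 150 nM and 2000 nM.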

Compound 3, half-maximal inhibitory concentration: 6310 nM
The estimate for compound 3 lay 13-fold (1.10 log units) below the measured number, and the stated range ends below it.
By their numbers in this assay, from the lowest: compound 1; then compound 3; then compound 2.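

With the nitrogen methyl kept, nitrile in place of methyl on the aromatic carbon gives a 16-fold higher number from compound 1 to compound 3 (1.20 log units; beyond the scatter) in this assay and so this carbon is sensitive to the group it carries. Exchanging 3,5-dimethyl-1H-pyrazol-4-yl for 3-cyano-1,5-dimethyl-1H-pyrazol-4-yl gives only a 2.5-fold lower number from compound 2 to compound 3 (0.40 log units; beyond the scatter) and so recovers just part of the earlier loss. No measurement available explains either step. Still open, going by these compounds, is how an amine, a carboxylic acid or an ethyl chain on this carbon would compare with methyl. Also open, on these data alone, is how a nitrile behaves with hydrogen on the aromatic nitrogen.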